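Working notes: the step from compound 1 to compound 4

The compounds below may be only part of what the source reports. "The series", "measured", "known", "first", "only" and "open" are said of these compounds alone.

- compound 1 `Cc1cccc(C)c1-c1cccc(COc2ccc(S(=O)(=O)CC(=O)O)cc2)c1` gives 2.49
- compound 2 `Cc1cc(OCC2CC2)cc(C)c1-c1cccc(COc2ccc(S(=O)(=O)CC(=O)O)cc2)c1` gives 3.46
- compound 3 `Cc1cc(OCCCS(C)(=O)=O)cc(C)c1-c1cccc(COc2ccc(S(=O)(=O)CC(=O)O)cc2)c1` gives "not determined" (no result reported)

In a physicochemical assay for lipophilicity, using the shake flask method, in phosphate buffer, measured as octanol-water partition, with a stated time of 24 h, at pH 7.4, tested at 100 uM (on this read-out lower numbers stand for lower lipophilicity and higher numbers for higher lipophilicity), compound 1 (2.49) holds the lower of the two numbers available. For the measured compounds named here, compound 2 holds the only other number, and compound 3 has no number to compare.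

The open case is compound 4 `CC(C)c1ccccc1-c1cccc(COc2ccc(S(=O)(=O)CC(=O)O)cc2)c1`, which differs from compound 1 in one place: 2-isopropylphenyl in place of 2,6-dimethylphenyl on an aromatic carbon with 2-isopropylphenyl in place of 2,6-dimethylphenyl on an aromatic carbon, meta to a large group. Both groups are carbon only and carry no net charge, and the entering group has the higher heavy-atom count.

Going by the values given here, no measured step exchanges these two groups. Among the compounds with values here, the only measured step, with cyclopropylmethoxy in place of hydrogen on an aromatic carbon, gives a number 0.97 log units higher from compound 1 to compound 2 (beyond the scatter) and is a different change, so it serves only as a loose upper guide. A much smaller step is expected here in this assay, directed towards a slightly higher number and probably not beyond the scatter. The estimated step is a number 0.21 log units higher from compound 1 to compound 4 (within the scatter) on this reasoning. For compound 4 the expected value is 2.7 with an estimated range from 2.35 to 3.1 for the measurement.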

Compound 4, distribution coefficient: 3.18
Estimate against measurement, compound 4: 0.48 log units below; measured number outside the range, above it.
By their numbers in this assay, from the lowest: compound 1; then compounds 4 and 2 (each within the scatter of the next).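

In this assay, 2-isopropylphenyl in place of 2,6-dimethylphenyl on an aromatic carbon, meta to a large group, gives a number 0.69 log units higher from compound 1 to compound 4 (beyond the scatter). The earlier step, a number 0.97 log units higher from compound 1 to compound 2 (beyond the scatter), added cyclopropylmethoxy in place of hydrogen; this result shows that the number also moves beyond the scatter when one carbon-only group is exchanged for another. The leaving group has 8 heavy atoms and the entering group 9, both have 0 hydrogen-bond donors, 0 hydrogen-bond acceptors and no net charge, and no measurement at hand accounts for the size of the step.

The exchange alters the aryl substituents in more than one way, so compound 1 and compound 4 alone cannot separate the contribution of the isopropyl group from that of the change away from 2,6-dimethyl, and a 2-methylphenyl or 2-ethylphenyl group would be needed to divide the step. Also open, from the compounds shown here alone, is how an aryl group carrying an amine or a carboxylic acid would read in this assay against compound 1 at 2.49.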